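Swapping the Sulfonamide Tail of a Squalene Monooxygenase Inhibitor

The source may report more compounds than this note shows. Statements on the series, on what has been measured and on what is new or still open speak of the compounds shown alone.

Compound 1, `CCN(C/C=C/C#CC(C)(C)C)Cc1cccc(OCCN(C)S(=O)(=O)c2nccs2)c1`: 170 nM
Compound 2, `CCN(C/C=C/C#CC(C)(C)C)Cc1cccc(OCCN(C)S(=O)(=O)c2cccnc2)c1`: 150 nM
Compound 3, `CCN(C/C=C/C#CC(C)(C)C)Cc1cccc(OCCN(C)S(=O)(=O)c2ccc(Br)s2)c1`: 390 nM

Of the compounds shown here, three with a shared core have been tested in a functional assay on HepG2 cells for inhibition of squalene monooxygenase (Homo sapiens); on this read-out lower numbers stand for stronger inhibition and higher numbers for weaker inhibition; they differ only in the aromatic group on the sulfonyl sulfur. In this assay compound 1 gives 170 nM and compound 2 gives 150 nM; the step of a 1.1-fold lower number from compound 1 to compound 2 (0.05 log units; within the scatter) is within the scatter, so these two cannot be ordered. Compound 3 stands at the highest number of the three, with a 2.3-fold higher number from compound 1 to compound 3 (0.36 log units; beyond the scatter) and a 2.6-fold higher number from compound 2 to compound 3 (0.41 log units; beyond the scatter), both modest but beyond the scatter.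

Compound 4, `CCN(C/C=C/C#CC(C)(C)C)Cc1cccc(OCCCS(=O)(=O)c2cccs2)c1`, changes the tail more deeply: a group of 9 heavy atoms (5 carbon, 2 oxygen, 2 sulfur; one five-membered aromatic ring with 1 hetero atom) in place of a group of 11 heavy atoms (5 carbon, 1 nitrogen, 2 oxygen, 2 sulfur, 1 bromine; one five-membered aromatic ring with 1 hetero atom), on a saturated chain carbon, two bonds along the chain from an oxygen on an aromatic ring. Among the compounds with values here, no measured step matches this change, so it can only be judged roughly. The two steps that bear on it show that exchanging the aromatic group at this end of the molecule shifts this assay by modest amounts in either direction, and nothing in the measured compounds suggests a large move.

Compound 4 is therefore expected to give a number near those of compound 1 and compound 2, a modest step down from compound 3: a 1.8-fold lower number from compound 3 to compound 4 (0.25 log units; within the scatter). The estimate for compound 4 is 220 nM, with a range from 90 nM to 550 nM.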

Compound 4, half-maximal inhibitory concentration: 290 nM
The estimate for compound 4 lay 1.3-fold (0.12 log units) below the measured number; the range from low to high includes it.
By their numbers in this assay, from the lowest: compounds 2, 1, 4 and 3 (each within the scatter of the next, the first and the last beyond it).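

In this assay, the tail tolerates more than an exchange of its aromatic ring: the group in compound 4 carries no nitrogen and no bromine, yet the result is a 1.3-fold lower number from compound 3 to compound 4 (0.13 log units; within the scatter), and the same holds for a 1.9-fold higher number from compound 2 to compound 4 (0.29 log units; within the scatter) and a 1.7-fold higher number from compound 1 to compound 4 (0.23 log units; within the scatter). So this deeper change at the saturated chain carbon gives no step beyond the scatter from any of the three earlier compounds, even though compound 2 and compound 3 are themselves separated, with a 2.6-fold higher number from compound 2 to compound 3 (0.41 log units; beyond the scatter), and compound 4 cannot be ranked against either of them. The available data offer no measurement that would explain these numbers.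

Compound 4 differs from compound 3 in both the nitrogen and the bromine at once, so the shown compounds cannot assign any part of the small step to either one, and a plain thiophen-2-yl group on the nitrogen-containing tail of compound 3 would separate the two. On these data alone, it also remains open whether the tail keeps this level of inhibition with a carboxylic acid or an amine at its end, or with a longer chain in front of the sulfonyl group.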